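This account rests on a few compounds, and the source may have more. Where it says the series, first, only, none or still open, it means among the compounds named here.

Three compounds have been measured in a functional assay on microsomes for inhibition, with a stated time of 1 h; on this read-out higher numbers stand for weaker inhibition and lower numbers for stronger inhibition:

- compound 1 `Cn1c(NN)nc(-c2cccc(O)c2O)c(C#N)c1=O`: 31 ug/mL
- compound 2 `CSc1nc(-c2cccs2)c(C#N)c(=O)n1C`: 83 ug/mL
- compound 3 `CCOC(=O)c1cnn(-c2nc(-c3ccccc3Cl)c(C#N)c(=O)n2C)c1N`: 102 ug/mL

Compound 2 stands with the second highest number of the three. Its nearest neighbour is compound 3, whose number lies within the usual scatter, so no order can be read between those two. Compound 1 gives a clearly lower number, beyond the scatter, and so inhibits more strongly than compound 2.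

Compound 4 `CSc1nc(-c2ccco2)c(C#N)c(=O)n1C` has not yet been measured. It differs from compound 2 in one place: furan-2-yl in place of thiophen-2-yl on an aromatic carbon. Going by the values given here, no measured pair shows this exchange, so there is nothing to set its size against. The step of a 1.1-fold higher number from compound 2 to compound 4 (0.04 log units; within the scatter) is expected to be small, not clearly beyond the scatter in either direction. In this assay compound 4 is expected to give about 90 ug/mL, with a range from 45 ug/mL to 180 ug/mL.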

Compound 4, half-maximal inhibitory concentration: 90 ug/mL
Estimate against measurement, compound 4: no gap at the digits printed, within the range that was stated.
By their numbers in this assay, from the lowest: compound 1; then compounds 2, 4 and 3 (each within the scatter of the next).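

Furan-2-yl in place of thiophen-2-yl on this aromatic carbon gives a 1.1-fold higher number from compound 2 to compound 4 (0.04 log units; within the scatter) in this assay, so this read-out does not separate the two groups. Going by these compounds alone, this is the first pair that differs in one place, and it shows that an oxygen can stand for the sulfur of this five-membered aromatic ring with no readable effect on the number. No measurement bears on why these two groups behave alike here. On these data alone, whether a ring-free group at this place, such as an amine or a carboxylic acid, would move the number beyond the scatter remains open.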